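Furyl replacement at the saturated ring carbon of compound 3

The source may report more compounds than this note shows. Statements on the series, on what has been measured and on what is new or still open speak of the compounds shown alone.

Among the compounds with values here, compound 3 `COc1cc(N2C(N)=C(C#N)C(c3cccc([N+](=O)[O-])c3)C3=C2CC(C)(C)CC3=O)cc(OC)c1OC` gives 30% in a functional assay on Ehrlich cells (Mus musculus) for cytotoxicity, tested at 100 ug/mL (a lower number here means a weaker effect, a higher number a stronger effect of the compound at the concentration tested), and stands second highest of the three numbers measured so far. Compound 1 `COc1cc(N2C(N)=C(C#N)C(/C=C/c3ccccc3)C3=C2CC(C)(C)CC3=O)cc(OC)c1OC` gives 40% in this assay, while compound 2 `COc1cc(N2C(N)=C(C#N)C(c3ccccc3O)C3=C2CC(C)(C)CC3=O)cc(OC)c1OC` gives 10%. All three share one core and differ only in the group on a saturated ring carbon: a number 30 percentage points lower from compound 1 to compound 2 (beyond the scatter); a number 10 percentage points lower from compound 1 to compound 3 (within the scatter); a number 20 percentage points higher from compound 2 to compound 3 (beyond the scatter). Exchanging the group at this position has therefore moved the read-out by a modest amount at most, and in one case not beyond the scatter.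

Compound 4 `COc1cc(N2C(N)=C(C#N)C(c3ccc(C)o3)C3=C2CC(C)(C)CC3=O)cc(OC)c1OC` has not yet been measured in this assay. The change from compound 3 is 5-methylfuran-2-yl in place of 3-nitrophenyl on a saturated ring carbon. It sits at the same position as all variation seen so far. Within the data shown here, no measured compound carries a five-membered aromatic ring there, so the direction cannot be read from the three steps; their sizes suggest a modest step at most. The expected change is a number 5 percentage points lower from compound 3 to compound 4 (within the scatter) in this assay. For compound 4 the estimate is 25%, with a range from 5% to 45%.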

Compound 4, a percentage reported as activity, at one concentration (the size of the read-out at that concentration, not a potency): 50%
Compound 4: middle estimate off by 25 percentage points, on the low side; the measured number lies above the stated range.
By their numbers in this assay, from the lowest: compound 2; then compounds 3, 1 and 4 (each within the scatter of the next, the first and the last beyond it).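

In this assay, within the data shown here, the 5-methylfuran-2-yl group shows that a five-membered aromatic ring with 1 hetero atom can replace a six-membered aromatic ring of carbon only on the saturated ring carbon without loss of read-out, with a number 20 percentage points higher from compound 3 to compound 4 (beyond the scatter) and a number 40 percentage points higher from compound 2 to compound 4 (beyond the scatter); the latter is the first large step seen at this position. Against the 2-phenylethenyl group the picture differs, with a number 10 percentage points higher from compound 1 to compound 4 (within the scatter), so these two groups cannot be told apart here. No supporting data on the origin of these steps are available.

The compounds shown leave open whether the step depends on the furan ring itself or on its methyl group. Unsubstituted furan-2-yl, thiophen-2-yl or a pyridine ring on this carbon would separate these contributions.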